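Branching the chain on the diene carbon of compound 1

This account rests on a few compounds, and the source may have more. Where it says the series, first, only, none or still open, it means among the compounds named here.

compound 1 `CCC/C(=C\C=C\C(=O)N[C@H](C)CCCc1cccnc1)c1ccc(OC)cc1` — 0.52 mg/kg
compound 2 `COc1ccc(C(=C/C=C/C(=O)NC(C)(C)CCCc2cccnc2)c2ccc(OC)cc2)cc1` — 0.27 mg/kg
compound 3 `C[C@H](CCCc1cccnc1)NC(=O)/C=C/C=C(c1cccc(F)c1)c1cccc(F)c1` — 0.22 mg/kg

In a functional assay with platelet-activating factor receptor (Cavia porcellus) as the target (a higher number here means that more compound is needed for the effect, a lower number that less compound is needed), compound 1 gives 0.52 mg/kg and stands at the highest of the three numbers. Compound 2 gives 0.27 mg/kg, a gap from compound 1 that lies within the scatter, so the two cannot be ordered. Compound 3 gives 0.22 mg/kg, which lies beyond the scatter from compound 1. Among the measured compounds shown here, no pair of the measured compounds differs in a single place, so no step is counted among them.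

Compound 4 `COc1ccc(/C(=C/C=C/C(=O)N[C@H](C)CCCc2cccnc2)C(C)C)cc1` is the one still to be measured. Against compound 1 the change is isopropyl in place of propyl on a double-bonded chain carbon bound to an aromatic carbon and a double-bonded chain carbon. The two have the same atoms, joined differently. For the measured compounds named here, nothing among the measured compounds varies at this spot, and the three measured values themselves span only a narrow band, so no step beyond the scatter is expected in this assay, in either direction. For compound 4 the estimate is 0.5 mg/kg, with a range from 0.2 mg/kg to 1.2 mg/kg. The expected step of a 1.0-fold lower number from compound 1 to compound 4 (0.02 log units; within the scatter) is accordingly small.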

Compound 4, dose for 50% inhibition: 0.41 mg/kg
Compound 4: the middle estimate sits 1.2-fold (0.09 log units) above what was measured; the measured number falls inside the stated range.
By their numbers in this assay, from the lowest: compounds 3, 2, 4 and 1 (each within the scatter of the next, the first and the last beyond it).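

In this assay, isopropyl in place of propyl on a double-bonded chain carbon bound to an aromatic carbon and a double-bonded chain carbon gives a 1.3-fold lower number from compound 1 to compound 4 (0.10 log units; within the scatter) and so no readable change. Among the compounds shown here, this is the only single-place step so far, and it shows that, on the core of compound 1, rearranging these three carbons from the straight chain to the branched one leaves the dose number indistinguishable from the parent. No measurement at hand bears on the result, so the flat step stands without an explanation.

Going by these compounds, whether this position responds to anything beyond a rearrangement of the same atoms remains open: a methyl, a cyclopropyl or a longer chain such as hexyl could still give a step beyond the scatter. A single pair also cannot show whether the same flat result would hold on a core carrying a different aryl group, such as the fluorophenyl.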